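A Difluorophenyl Variant of Compound 1 in Cytotoxicity Testing

The compounds below may be only part of what the source reports. "The series", "measured", "known", "first", "only" and "open" are said of these compounds alone.

Compound 1 `COc1cc(-c2cc(/C=C/C(=O)c3ccc(N)cc3)[nH]n2)cc(OC)c1OC`: 81%
Compound 2 `COc1ccc(C(=O)/C=C/c2cc(-c3cc(OC)c(OC)c(OC)c3)n[nH]2)cc1OC`: 74%
Compound 3 `COc1ccc(C(=O)/C=C/c2cc(-c3cc(OC)c(OC)c(OC)c3)n[nH]2)cc1`: 94%

These three compounds were tested in a functional assay on 786-0 cells (Homo sapiens) for cytotoxicity, read by sulforhodamine B assay, with a stated time of 48 h, tested at 1 uM; a lower number here means a stronger effect, a higher number a weaker effect of the compound at the concentration tested. Among them compound 1 stands second highest; the nearest step is a number 7 percentage points lower from compound 1 to compound 2 (within the scatter), and the furthest is a number 13 percentage points higher from compound 1 to compound 3 (beyond the scatter). Compound 4 `COc1cc(-c2cc(/C=C/C(=O)c3ccc(F)c(F)c3)[nH]n2)cc(OC)c1OC` has not yet been measured. It differs from compound 1 in one place: 3,4-difluorophenyl in place of 4-aminophenyl on a carbonyl carbon. Within the data shown here, the only measured step at the same carbonyl carbon is a number 7 percentage points lower from compound 1 to compound 2 (within the scatter), which changed the read-out little. Among the measured compounds shown here, no measured compound carries the 3,4-difluorophenyl group, so the expectation rests on that step alone: no step beyond the scatter is expected, a number 1 percentage points higher from compound 1 to compound 4 (within the scatter). Compound 4 is therefore estimated at 82%, with a range from 65% to 98%.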

Compound 4, a percentage reported as activity, at one concentration (the size of the read-out at that concentration, not a potency): 93%
Compound 4: the middle estimate sits 11 percentage points below what was measured; measured number inside the range.
By their numbers in this assay, from the lowest: compounds 2 and 1 (each within the scatter of the next); then compounds 4 and 3 (each within the scatter of the next).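

In this assay, the group on the carbonyl carbon can now be seen to matter, since the earlier step there stayed within the scatter. Placing 3,4-difluorophenyl there gives a number 12 percentage points higher from compound 1 to compound 4 (beyond the scatter) and a number 19 percentage points higher from compound 2 to compound 4 (beyond the scatter), both towards a weaker effect. Against the 4-methoxyphenyl group, the same change gives a number 1 percentage points lower from compound 3 to compound 4 (within the scatter), so these two groups cannot be told apart here. As far as these compounds go, whether 4-hydroxyphenyl or 4-fluorophenyl at this carbon would restore any effect remains open. Nothing available explains why these groups differ.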